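From Methyl to 4-Chlorophenyl on the Shared Core

The compounds below may be only part of what the source reports. "The series", "measured", "known", "first", "only" and "open" are said of these compounds alone.

In a functional assay on MOLT-4 cells (Homo sapiens) for cytotoxicity, read by CCK-8 assay, with a stated time of 24 h (on this read-out higher numbers stand for weaker inhibition and lower numbers for stronger inhibition), compound 1 `C=CC(=O)N1C(=O)CC(c2ccc(OC)cc2)Sc2ccccc21` gives 83200 nM, and compound 2 `C=CC(=O)N1C(=O)CC(C)Sc2ccccc21` gives 730000 nM. Compound 2 thus holds the higher of the two numbers, which on this read-out stands for the weaker inhibition. Compound 3 `C=CC(=O)N1C(=O)CC(c2ccc(Cl)cc2)Sc2ccccc21` has not yet been measured. It differs from compound 2 by 4-chlorophenyl in place of methyl on a saturated ring carbon, with 4-chlorophenyl in place of methyl on a saturated ring carbon.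

For the measured compounds named here, only one measured step bears on this change: an 8.8-fold higher number from compound 1 to compound 2 (0.94 log units; beyond the scatter), beyond the scatter, where methyl replaces 4-methoxyphenyl on a saturated ring carbon. The change to compound 3 runs the opposite way, from methyl to a group that also carries a six-membered aromatic ring of carbon only. Going by the values given here, a step of similar size towards a lower number is therefore expected in this assay, although no measured pair compares 4-chlorophenyl with 4-methoxyphenyl directly. The expected step is a 10-fold lower number from compound 2 to compound 3 (1.02 log units; beyond the scatter). For compound 3 the estimated value is 70000 nM, with an expected range of 25000 nM to 200000 nM.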

Compound 3, half-maximal inhibitory concentration: 82400 nM
Compound 3: middle estimate off by 1.2-fold (0.07 log units), on the low side; the measured number falls inside the stated range.
By their numbers in this assay, from the lowest: compounds 3 and 1 (each within the scatter of the next); then compound 2.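

On this saturated ring carbon next to the ring sulfur, the change from methyl to 4-chlorophenyl in this assay gives an 8.9-fold lower number from compound 2 to compound 3 (0.95 log units; beyond the scatter), so the separation from methyl seen with 4-methoxyphenyl now also holds for a second group carrying a six-membered aromatic ring of carbon only. Chloro in place of methoxy on an aromatic carbon gives a 1.0-fold lower number from compound 1 to compound 3 (0.00 log units; within the scatter), so these two substituents on the aromatic ring cannot be told apart on this read-out. No measurement bears on why either group separates from methyl in this way.

The compounds shown leave open whether an unsubstituted phenyl group, or a longer chain such as n-butyl in place of methyl, would stand with compound 3 or with compound 2. They also leave open how an amine or a carboxylic acid on the aromatic ring would read, and what would follow if a propanoyl group took the place of the vinylcarbonyl group on the ring nitrogen.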